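Swapping the aryl group on a glycoside hydrazone

The source may report more compounds than this note shows. Statements on the series, on what has been measured and on what is new or still open speak of the compounds shown alone.

Measured so far in a functional assay on MDA-MB-231 cells (Homo sapiens) for inhibition, read by MTT assay, with a stated time of 24 h, tested at 100 uM; a lower number here means less inhibition, a higher number more inhibition at the concentration tested (going by the name of the read-out):
compound 1 `N#Cc1cccc(/C=N/NC(=O)c2ccc(O[C@@H]3O[C@H](CO)[C@@H](O)[C@H](O)[C@H]3O)cc2)c1` gives 6.17%
compound 2 `O=C(N/N=C/c1ccc(Cl)cc1)c1ccc(O[C@@H]2O[C@H](CO)[C@@H](O)[C@H](O)[C@H]2O)cc1` gives 2.26%
compound 3 `CC(=O)OC[C@H]1O[C@@H](Oc2ccc(-c3nnc(-c4ccc([N+](=O)[O-])cc4)o3)cc2)[C@H](OC(C)=O)[C@@H](OC(C)=O)[C@@H]1OC(C)=O` gives 58%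

Compound 1 sits second highest of these three numbers; its gap to compound 2 lies within the scatter, while compound 3 stands far above it, beyond the scatter. Compound 4 `Cc1ccc(/C=N/NC(=O)c2ccc(O[C@@H]3O[C@H](CO)[C@@H](O)[C@H](O)[C@H]3O)cc2)cc1` differs from compound 1 in one place: 4-methylphenyl in place of 3-cyanophenyl on a carbon with a double bond to nitrogen. Within the data shown here, the only measured step at the same place is a number 3.9 percentage points lower from compound 1 to compound 2 (within the scatter), a change within the scatter. A step of that kind is therefore expected here too, with no move beyond the scatter, giving a number 2.2 percentage points lower from compound 1 to compound 4 (within the scatter). Compound 4 is thus estimated at 4% in this assay, within a range from 0% to 15%.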

Compound 4, a percentage reported as inhibition, at one concentration (the size of the read-out at that concentration, not a potency): 9.28%
Compound 4: middle estimate off by 5.3 percentage points, on the low side; the measured number falls inside the stated range.
By their numbers in this assay, from the lowest: compounds 2, 1 and 4 (each within the scatter of the next); then compound 3.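

Putting 4-methylphenyl in place of 3-cyanophenyl on the carbon with a double bond to nitrogen gives a number 3.1 percentage points higher from compound 1 to compound 4 (within the scatter) in this assay, and methyl in place of chloro on an aromatic carbon gives a number 7 percentage points higher from compound 2 to compound 4 (within the scatter). The three aryl groups now tested at this position, carrying nitrile, chloro or methyl, all give numbers within the scatter of one another, so no swap here has yet moved the read-out beyond it. No other data on hand bear on this result. As far as these compounds go, whether an amine or a carboxylic acid on this aromatic ring would move the number beyond the scatter stays open.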